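Coumarin-triazole lipoamide series: bromophenyl variant

A few compounds are considered here, and "the series" means these few. Any claim that something is new, unique, unknown or untested is made for them only; others in the source may bear on it.

Measured in a functional assay on PC-12 cells (Rattus norvegicus) for cytotoxicity, read by MTT assay, with stated times of 3 h and 2 h, tested at 1 uM; a higher number here means a stronger effect of the compound at the concentration tested, a lower number a weaker effect:
compound 1 `CC(=O)c1cc2ccc(OCCCCCn3cc(CNC(=O)CCCCC4CCSS4)nn3)cc2oc1=O` gives 27.4%
compound 2 `COc1ccc(-c2cc3ccc(OCCCCCn4cc(CNC(=O)CCCCC5CCSS5)nn4)cc3oc2=O)cc1OC` gives 42.2%

Going by the values given here, compound 2 stands highest of the two numbers so far in this assay; its nearest neighbour is compound 1, and the step of a number 14.8 percentage points higher from compound 1 to compound 2 (beyond the scatter) lies beyond the scatter.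

Compound 3 `O=C(CCCCC1CCSS1)NCc1cn(CCCCCOc2ccc3cc(-c4ccc(Br)cc4)c(=O)oc3c2)nn1` is the next variant. The change from compound 2 is 4-bromophenyl in place of 3,4-dimethoxyphenyl on an aromatic carbon.

Among the compounds with values here, no measured step bears directly on this change: the only step available, a number 14.8 percentage points higher from compound 1 to compound 2 (beyond the scatter), concerns an acetyl against an aryl group, not one aryl group against another. It shows only that the substituent at this position can move the read-out modestly. With no comparable swap on record, the expectation for compound 3 is a step of a number 2.2 percentage points lower from compound 2 to compound 3 (within the scatter), that is, no change beyond the scatter. Compound 3 is therefore estimated at 40%, with a range from 26% to 54%.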

Compound 3, a percentage reported as activity, at one concentration (the size of the read-out at that concentration, not a potency): 43.7%
For compound 3 the middle estimate is 3.7 percentage points below the measured one; low and high end bracket the measured number.
By their numbers in this assay, from the lowest: compound 1; then compounds 2 and 3 (each within the scatter of the next).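

The step of a number 1.5 percentage points higher from compound 2 to compound 3 (within the scatter) in this assay shows that this assay does not separate 4-bromophenyl from 3,4-dimethoxyphenyl at this position, even though the entering group has fewer heavy atoms and no hydrogen-bond acceptors. The step of a number 16.3 percentage points higher from compound 1 to compound 3 (beyond the scatter) runs alongside the earlier step of a number 14.8 percentage points higher from compound 1 to compound 2 (beyond the scatter), so among these compounds the read-out separates acetyl from both aryl groups, but not one aryl group from the other. No measurement on hand accounts for either result.

Still open, going by these compounds, is whether a phenyl ring carrying an amine or a carboxylic acid would stay with these two aryl groups, or a longer alkyl chain would fall nearer the acetyl compound. Readings at a single concentration also tell only whether the effect of these compounds is stronger or weaker at that concentration.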